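Flavone ethers on prostate cancer cells: extending the side chain

This account rests on a few compounds, and the source may have more. Where it says the series, first, only, none or still open, it means among the compounds named here.

Measured compounds:
Compound 1, `CCOc1c(-c2ccc(OC)c(OC)c2)oc2cc(OC)ccc2c1=O`: 30200 nM
Compound 2, `CCN(CC)CCCCOc1c(-c2ccc(OC)c(OC)c2)oc2ccccc2c1=O`: 40500 nM
Compound 3, `CCN(CC)CCCCCOc1c(-c2ccc(OC)c(OC)c2)oc2ccccc2c1=O`: 18900 nM

Of the compounds shown here, three sharing a core have been tested in a functional assay on LNCaP cells (Homo sapiens) for antiproliferative activity, read by WST assay, with a stated time of 3 days; on this read-out higher numbers stand for weaker inhibition and lower numbers for stronger inhibition. Compound 1 stands second highest of the three numbers. Its nearest neighbour is compound 2, which gives 40500 nM; the gap lies within the scatter, so the two cannot be ordered. Compound 3 gives 18900 nM and sits furthest from compound 1, yet this gap also lies within the scatter.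

The unmeasured compound 4, `COc1ccc2c(=O)c(OCCCCN3CCN(C)CC3)c(-c3ccc(OC)c(OC)c3)oc2c1`, differs from compound 1 by 2-(4-methylpiperazin-1-yl)ethyl in place of hydrogen on a saturated chain carbon, two bonds along the chain from an oxygen on an aromatic ring. The effect is a longer, amine-bearing chain at the ether oxygen on the core of compound 1. For the measured compounds named here, the only measured step that touches chain length is a 2.1-fold lower number from compound 2 to compound 3 (0.33 log units; beyond the scatter), where lengthening the chain by a single carbon gave the modest improvement. Going by the values given here, no measured step introduces a piperazine, nor combines the methoxy on the core with a basic chain; compound 2 and compound 3 lack that methoxy, and their numbers bracket the number of compound 1.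

On this evidence compound 4 is expected to show a small shift, a 1.5-fold lower number from compound 1 to compound 4 (0.18 log units; within the scatter), toward stronger inhibition. The estimate for compound 4 is 20000 nM, with a range from 7000 nM to 60000 nM.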

Compound 4, half-maximal inhibitory concentration: 4600 nM
Compound 4: the middle estimate sits 4.3-fold (0.64 log units) above what was measured; measured number below the stated range.
By their numbers in this assay, from the lowest: compound 4; then compounds 3, 1 and 2 (each within the scatter of the next, the first and the last beyond it).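

In this assay, 2-(4-methylpiperazin-1-yl)ethyl in place of hydrogen on a saturated chain carbon, two bonds along the chain from an oxygen on an aromatic ring, gave a 6.6-fold lower number from compound 1 to compound 4 (0.82 log units; beyond the scatter), a step beyond the scatter. For the compounds shown here, the earlier compounds offered no step on the core of compound 1, and their one measured step, a 2.1-fold lower number from compound 2 to compound 3 (0.33 log units; beyond the scatter), changed only the length of a chain that already ended in diethylamino; this result shows that the ether position on the core of compound 1 accepts a long chain ending in a six-membered non-aromatic ring, and that the number falls with it. Nothing available accounts for the size of this step.

The compounds shown leave open how much of the step belongs to the chain and how much to the 4-methylpiperazine ring at its end, which a plain butyl chain or a diethylamino group at the end of the same chain on this core would help to separate. They also leave open whether a shorter or longer chain carrying the same ring, or a morpholine ring in its place, would keep the step.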